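Swapping a Bromophenyl Amide for an Ethylphenyl Amide

The source may report more compounds than this note shows. Statements on the series, on what has been measured and on what is new or still open speak of the compounds shown alone.

Compound 1 `O=C(CSc1nc(Nc2ccccc2)c2ccccc2n1)Nc1ccccc1Br`: 14100 nM
Compound 2 `O=C(CSc1nc(Nc2ccccc2)c2ccccc2n1)Nc1cccc(Br)c1`: 17500 nM
Compound 3 `O=C(CSc1nc(Nc2ccccc2)c2ccccc2n1)Nc1ccc(Cl)cc1`: 17200 nM

Three amides built on a shared core have been measured in a functional assay on MDA-MB-231 cells (Homo sapiens) for inhibition, read by MTT assay, with a stated time of 72 h; a higher number here means a weaker inhibitor, a lower number a stronger inhibitor. In this assay compound 2 gives 17500 nM, the highest of the three numbers, yet every step to its neighbours lies within the scatter: a 1.2-fold higher number from compound 1 to compound 2 (0.09 log units; within the scatter) and a 1.0-fold lower number from compound 2 to compound 3 (0.01 log units; within the scatter). The same holds for a 1.2-fold higher number from compound 1 to compound 3 (0.09 log units; within the scatter), so nothing separates these three aryl amides on the evidence shown.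

Compound 4 `CCc1ccc(NC(=O)CSc2nc(Nc3ccccc3)c3ccccc3n2)cc1` has not yet been measured. It differs from compound 2 in one place: 4-ethylphenyl in place of 3-bromophenyl on an amide-type nitrogen. Among the compounds with values here, the steps that bear on this change are the three aryl swaps on the same amide-type nitrogen, and each of them was within the scatter. On that basis the step of a 1.1-fold lower number from compound 2 to compound 4 (0.04 log units; within the scatter) from compound 2 to compound 4 is expected to be small and in no particular direction. For compound 4 the value expected in this assay is 16000 nM, within a range of 7000 nM to 36000 nM.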

Compound 4, half-maximal inhibitory concentration: 33900 nM
For compound 4 the middle estimate is 2.1-fold (0.33 log units) below the measured one, and the stated range covers the measured number.
By their numbers in this assay, from the lowest: compounds 1, 3, 2 and 4 (each within the scatter of the next, the first and the last beyond it).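

In this assay the 4-ethylphenyl amide yields the only step among these aryl amides that passes the scatter, and only a modest one (a 2.4-fold higher number from compound 1 to compound 4 (0.38 log units; beyond the scatter)), so compound 4 is a weaker inhibitor than compound 1. Within the data shown here, its other two steps stay within the scatter (a 1.9-fold higher number from compound 2 to compound 4 (0.29 log units; within the scatter); a 2.0-fold higher number from compound 3 to compound 4 (0.29 log units; within the scatter)), including the single swap of ethyl in place of chloro on an aromatic carbon, so compound 4 is not separated from compound 2 or compound 3. The position on the amide-type nitrogen therefore shows some sensitivity to the aryl group, but nothing shown accounts for it.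

As far as these compounds go, it remains open whether a propyl chain, a methoxy group or a carboxylic acid on that phenyl ring would widen this modest gap. Whether an amine in place of the phenyl ring would keep any activity in this assay is also unresolved.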